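Ring-opened ether with a methoxy group replaces the indane

This account rests on a few compounds, and the source may have more. Where it says the series, first, only, none or still open, it means among the compounds named here.

Measured compounds in an assay on microsomes from liver for inhibition of acyl-CoA desaturase 1 (Rattus norvegicus); on this read-out higher numbers stand for weaker inhibition and lower numbers for stronger inhibition:
Compound 1 `Cc1ccccc1OC1CCN(c2ccc(-n3ccnc3)nn2)CC1` gives 39 nM.
Compound 2 `Brc1ccccc1OC1CCN(c2ccc(-n3ccnc3)nn2)CC1` gives 5 nM.
Compound 3 `c1cc2c(c(OC3CCN(c4ccc(-n5ccnc5)nn4)CC3)c1)CCC2` gives 10 nM.

Compound 3 stands second highest of the three numbers. Its nearest neighbour is compound 2, where the gap is a 2.0-fold higher number from compound 2 to compound 3 (0.30 log units; within the scatter), so these two cannot be told apart. The larger gap is to compound 1, a 3.9-fold lower number from compound 1 to compound 3 (0.59 log units; beyond the scatter).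

Compound 4 `COc1ccccc1OC1CCN(c2ccc(-n3ccnc3)nn2)CC1` differs from compound 3 in one place: 2-methoxyphenyl in place of 2,3-dihydro-1H-inden-4-yl on an oxygen on a saturated carbon. For the measured compounds named here, no measured step shows exactly this change. The one that comes closest is a 3.9-fold lower number from compound 1 to compound 3 (0.59 log units; beyond the scatter), since compound 1 also carries a single six-membered aromatic ring with one small substituent on the ether oxygen, and compound 4 returns to that pattern. Read backwards, that step suggests a modest rise when the 2,3-dihydro-1H-inden-4-yl group is given up. The step of a 7.8-fold lower number from compound 1 to compound 2 (0.89 log units; beyond the scatter) shows that the choice of substituent on that ring matters, and a methoxy group has not been tested here, so the size of the shift remains uncertain.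

On this basis compound 4 is expected to show a 2.5-fold higher number from compound 3 to compound 4 (0.40 log units; beyond the scatter) in this assay, landing at an estimated 25 nM, with a likely range from 8 nM to 80 nM.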

Compound 4, half-maximal inhibitory concentration: 543 nM
Compound 4: the middle estimate sits 22-fold (1.34 log units) below what was measured; the whole stated range lies below it.
By their numbers in this assay, from the lowest: compounds 2 and 3 (each within the scatter of the next); then compound 1; then compound 4.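

In this assay, this aromatic carbon does not treat all small groups alike: methoxy in place of bromo gives the largest step in the set (a 110-fold higher number from compound 2 to compound 4 (2.04 log units; beyond the scatter)), and methoxy in place of methyl also gives a large one (a 14-fold higher number from compound 1 to compound 4 (1.14 log units; beyond the scatter)). The change from 2,3-dihydro-1H-inden-4-yl to 2-methoxyphenyl on the ether oxygen is large as well (a 54-fold higher number from compound 3 to compound 4 (1.73 log units; beyond the scatter)), even though the two groups are close in size by count, with 9 heavy atoms leaving and 8 entering, so heavy-atom count alone does not track the read-out across this pair. The entering group has 1 hydrogen-bond acceptor where the leaving group has 0, but this is only a difference in structure, and no measurement in hand gives a cause for these steps.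

The compounds shown leave open whether the oxygen of the methoxy group or the group as a whole goes with the higher number. An ethyl group, a hydroxy group or an ethoxy group on the same aromatic carbon would help separate these possibilities.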